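Chain lengthening on the anilide of the shared core

This account rests on a few compounds, and the source may have more. Where it says the series, first, only, none or still open, it means among the compounds named here.

Compound 1 `CCC(=O)Nc1ccc(S(=O)(=O)Oc2ccccc2C(C)C)cc1` gives 2100 nM in a functional assay on HT-1080 cells (Homo sapiens) for antiproliferative activity, read by sulforhodamine B assay, with a stated time of 48 h; a lower number here means a stronger inhibitor, a higher number a weaker inhibitor. Among the measured compounds shown here, compound 2 `CCCC(=O)Nc1ccc(S(=O)(=O)Oc2ccccc2C(C)C)cc1` gives 950 nM in this assay, the lowest of the two numbers so far, with compound 1 as its nearest neighbour. For the measured compounds named here, the one recorded step, a 2.2-fold lower number from compound 1 to compound 2 (0.34 log units; beyond the scatter), runs in the same direction as the change now considered. Compound 3 `CCCCCC(=O)Nc1ccc(S(=O)(=O)Oc2ccccc2C(C)C)cc1` differs from compound 2 by ethyl in place of hydrogen on a saturated chain carbon, three bonds along the chain from a carbonyl carbon. Going by the values given here, only that single step bears on it; it was modest, and a further lengthening need not repeat it. A modest further decrease is nonetheless expected, a 1.7-fold lower number from compound 2 to compound 3 (0.24 log units; within the scatter). Compound 3 is estimated at 550 nM in this assay, within 200 nM to 1600 nM.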

Compound 3, half-maximal inhibitory concentration: 6300 nM
For compound 3 the middle estimate is 11-fold (1.06 log units) below the measured one, outside the stated range (above it).
By their numbers in this assay, from the lowest: compound 2; then compound 1; then compound 3.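

The gain from lengthening does not continue at this position: in this assay, ethyl in place of hydrogen gives a 6.6-fold higher number from compound 2 to compound 3 (0.82 log units; beyond the scatter), reversing the earlier decrease. Compound 3 also falls behind the shorter chain, with a 3.0-fold higher number from compound 1 to compound 3 (0.48 log units; beyond the scatter), so across these compounds the number does not move in one direction as the chain grows. No available measurement accounts for this reversal.

Still open, from the compounds shown here alone, is whether a longer chain continues the rise seen with compound 3. Also open, going by these compounds, is whether a chain carrying an amine or a carboxylic acid behaves differently in this assay.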